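Ortho versus Para Chloro on the Urea Aryl Ring

The source may report more compounds than this note shows. Statements on the series, on what has been measured and on what is new or still open speak of the compounds shown alone.

Compound 1 `CCOc1ccc(NC(=O)Nc2cccc(CNc3nccnc3Cl)c2)cc1` gives 7050 nM in a functional assay on HepG2 cells (Homo sapiens) for antiproliferative activity, read by MTT assay, with a stated time of 48 h; a lower number here means a stronger inhibitor, a higher number a weaker inhibitor. Compound 2 `O=C(Nc1ccc(Cl)cc1)Nc1cccc(CNc2nccnc2Cl)c1` gives 8350 nM. Compound 3 `CCc1ccccc1NC(=O)Nc1cccc(CNc2nccnc2Cl)c1` gives 7860 nM.

Compound 2 sits at the upper end of these three numbers, but the gap a 1.1-fold lower number from compound 2 to compound 3 (0.03 log units; within the scatter) and the gap a 1.2-fold higher number from compound 1 to compound 2 (0.07 log units; within the scatter) both lie within the scatter, so the three compounds cannot be told apart. Compound 4 `O=C(Nc1cccc(CNc2nccnc2Cl)c1)Nc1ccccc1Cl` differs from compound 2 by 2-chlorophenyl in place of 4-chlorophenyl on an amide-type nitrogen. Among the compounds with values here, the steps that bear on this are those which also exchange the aryl group on the amide-type nitrogen: a 1.1-fold higher number from compound 1 to compound 3 (0.05 log units; within the scatter) and a 1.1-fold lower number from compound 2 to compound 3 (0.03 log units; within the scatter), neither beyond the scatter. No step beyond the scatter is therefore expected in this assay: compound 4 is estimated at 8000 nM, with a range of 4000 nM to 16000 nM, an expected step of a 1.0-fold lower number from compound 2 to compound 4 (0.02 log units; within the scatter).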

Compound 4, half-maximal inhibitory concentration: 8560 nM
Compound 4: middle estimate off by 1.1-fold (0.03 log units), on the low side; low and high end bracket the measured number.
By their numbers in this assay, from the lowest: compounds 1, 3, 2 and 4 (each within the scatter of the next).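

Exchanging 4-chlorophenyl for 2-chlorophenyl on the amide-type nitrogen gives a 1.0-fold higher number from compound 2 to compound 4 (0.01 log units; within the scatter) in this assay, so the place of the chloro on this aryl group makes no readable difference here. The other two new steps, a 1.1-fold higher number from compound 3 to compound 4 (0.04 log units; within the scatter) and a 1.2-fold higher number from compound 1 to compound 4 (0.08 log units; within the scatter), are just as small, and all four aryl groups shown on this nitrogen remain indistinguishable. The compounds shown leave open whether a carboxylic acid or an amine on this aryl group, or a longer chain in place of ethoxy, would give a step beyond the scatter. No evidence is available that bears on this result.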